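Two Hydroxymethyl Groups on One Fused Core

This account rests on a few compounds, and the source may have more. Where it says the series, first, only, none or still open, it means among the compounds named here.

Compound 3 `Cc1cc(CO)c2n1[C@@H](c1ccccc1)SC2` gives 63900 nM in a functional assay on MCF7 cells (Homo sapiens) for cytotoxicity, read by MTT assay, with a stated time of 48 h (on this read-out lower numbers stand for stronger inhibition and higher numbers for weaker inhibition), and stands highest among the three measured numbers. Compound 1 `COC(=O)c1cc2n(c1C)[C@@H](c1ccccc1)SC2` gives 55500 nM, within the scatter of compound 3, while compound 2 `Cc1c(CO)cc2n1[C@@H](c1ccccc1)SC2` gives 4300 nM, far lower. Going by the values given here, the only measured step, a 13-fold lower number from compound 1 to compound 2 (1.11 log units; beyond the scatter), concerns a different exchange and does not bear directly on the present change. Compound 4 `Cc1c(CO)c(CO)c2n1[C@@H](c1ccccc1)SC2` differs from compound 3 by hydroxymethyl in place of hydrogen on an aromatic carbon, so that it carries the hydroxymethyl groups of both compound 2 and compound 3. Since compound 2 with its hydroxymethyl gives 4300 nM, a lower number is expected for compound 4, by about a 5.3-fold lower number from compound 3 to compound 4 (0.73 log units; beyond the scatter). Compound 4 is therefore estimated at 12000 nM, within 3000 nM to 45000 nM.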

Compound 4, half-maximal inhibitory concentration: 1900 nM
Compound 4: the middle estimate sits 6.3-fold (0.80 log units) above what was measured; measured number below the stated range.
By their numbers in this assay, from the lowest: compound 4; then compound 2; then compounds 1 and 3 (each within the scatter of the next).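

In this assay, going by these compounds alone, hydroxymethyl in place of hydrogen on this aromatic carbon gives a large change (a 34-fold lower number from compound 3 to compound 4 (1.53 log units; beyond the scatter)), the first view of this position, as the only earlier step exchanged methoxycarbonyl. The same exchange at the other hydroxymethyl-bearing carbon gives only a modest change (a 2.3-fold lower number from compound 2 to compound 4 (0.35 log units; beyond the scatter)), so the two positions do not contribute equally. Nothing available here explains this difference. As far as these compounds go, whether an amine, a carboxylic acid or a longer chain ending in hydroxyl would do as well on this carbon remains open.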